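Compound 2 to compound 3: a smaller group on the core

This account rests on a few compounds, and the source may have more. Where it says the series, first, only, none or still open, it means among the compounds named here.

Compound 1 `O=C(Nc1ccccc1)Nc1nc(Sc2c[nH]c3ccccc23)cc(N2CCCC2)n1` measured at 7890 nM
Compound 2 `O=C(Nc1ccccc1)Nc1nc(Sc2c[nH]c3ccccc23)cc(N2CCN(c3ccccn3)CC2)n1` measured at 19500 nM

In a functional assay on MDA-MB-231 cells (Homo sapiens) for inhibition, with a stated time of 72 h (on this read-out lower numbers stand for stronger inhibition and higher numbers for weaker inhibition), compound 2 has the higher of the two numbers, which makes it the weaker inhibitor of this pair. Compound 3 `O=C(Nc1ccccc1)Nc1nc(Sc2c[nH]c3ccccc23)cc(N2CCCCC2)n1` keeps the shared core and changes one group: piperidin-1-yl in place of 4-(pyridin-2-yl)piperazin-1-yl on an aromatic carbon and nothing else.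

For the measured compounds named here, only one measured step bears on this change. It is a 2.5-fold higher number from compound 1 to compound 2 (0.39 log units; beyond the scatter) and it brought in the same large group, there in place of pyrrolidin-1-yl. Compound 3 removes that group again, and piperidin-1-yl looks much more like the pyrrolidin-1-yl of compound 1 than like the group it replaces. Going by the values given here, one step is thin evidence, and no measured compound shows what the change of ring size alone does. Even so, a modest move to a lower number, meaning stronger inhibition, is expected in this assay for this change. The expected size is a 2.2-fold lower number from compound 2 to compound 3 (0.34 log units; beyond the scatter) by this estimate. For compound 3 the estimated value is 9000 nM with a likely range from 4500 nM to 18000 nM in this test.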

Compound 3, half-maximal inhibitory concentration: 8130 nM
Compound 3: middle estimate off by 1.1-fold (0.04 log units), on the high side, within the range that was stated.
By their numbers in this assay, from the lowest: compounds 1 and 3 (each within the scatter of the next); then compound 2.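

Going back from 4-(pyridin-2-yl)piperazin-1-yl to a small ring at this position gives a 2.4-fold lower number from compound 2 to compound 3 (0.38 log units; beyond the scatter) in this assay, so the change seen between compound 1 and compound 2 now has a counterpart in a second pair of compounds. Swapping one small ring for the other gives a 1.0-fold higher number from compound 1 to compound 3 (0.01 log units; within the scatter), which means that pyrrolidin-1-yl and piperidin-1-yl cannot be told apart in this assay, and of the three compounds only compound 2, with the larger group, stands apart as the weaker inhibitor. No measurement here explains why the larger group goes with the higher number.

The compounds shown do not separate the part played by the pyridin-2-yl ring from that of the piperazine ring carrying it, a question that a plain piperazin-1-yl or a 4-methylpiperazin-1-yl group at the same carbon would address. As far as these compounds go, it also remains open how this position responds to a morpholin-4-yl ring or to an open-chain amine such as dimethylamino.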